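From pyridin-2-yl to 4-methylphenyl on a shared core

The compounds below may be only part of what the source reports. "The series", "measured", "known", "first", "only" and "open" are said of these compounds alone.

In a functional assay on B16-F10 cells (Mus musculus) for antiproliferative activity, read by MTT assay, with a stated time of 48 h (on this read-out lower numbers stand for stronger inhibition and higher numbers for weaker inhibition), compound 1 `CC(=O)N1N=C(c2ccc3ccccc3c2)OC1c1ccccc1Cl` gives 4.93 ug/mL and compound 2 `CC(=O)N1N=C(c2ccc3ccccc3c2)OC1c1ccccn1` gives 7.18 ug/mL. Within the data shown here, these are the only two numbers available, and they lie within the scatter of each other, so compound 2 cannot be ranked against compound 1. Compound 3 `CC(=O)N1N=C(c2ccc3ccccc3c2)OC1c1ccc(C)cc1` has not yet been measured. It keeps the shared core and differs from compound 2 as follows: 4-methylphenyl in place of pyridin-2-yl on a saturated ring carbon. In short, 4-methylphenyl stands in place of pyridin-2-yl on a saturated ring carbon. Among the measured compounds shown here, one measured step bears on this change, the exchange of 2-chlorophenyl for pyridin-2-yl at that same carbon. For the measured compounds named here, the data hold no measured example of the 4-methylphenyl group itself. Because a 1.5-fold higher number from compound 1 to compound 2 (0.16 log units; within the scatter) stayed within the scatter, no step beyond the scatter is expected for compound 3 in this assay. The expected step is a 1.3-fold lower number from compound 2 to compound 3 (0.12 log units; within the scatter), a small one that leaves the two numbers within the scatter. For compound 3 the estimated value is 5.5 ug/mL, with an expected range from 2.5 ug/mL to 12 ug/mL.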

Compound 3, half-maximal inhibitory concentration: 3.85 ug/mL
Compound 3: middle estimate off by 1.4-fold (0.15 log units), on the high side; measured number inside the range.
By their numbers in this assay, from the lowest: compounds 3, 1 and 2 (each within the scatter of the next).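

In this assay, the 4-methylphenyl group now joins 2-chlorophenyl and pyridin-2-yl on this saturated ring carbon, and neither exchange leads beyond the scatter: replacing pyridin-2-yl gives a 1.9-fold lower number from compound 2 to compound 3 (0.27 log units; within the scatter), and replacing 2-chlorophenyl gives a 1.3-fold lower number from compound 1 to compound 3 (0.11 log units; within the scatter). The earlier pair held two rings that both carried a hetero atom or a halogen, whereas here a ring of carbon only, with no hydrogen-bond acceptor in place of the one counted on pyridin-2-yl, still gives no step beyond the scatter, so across these three compounds the number does not depend measurably on which of the three groups stands at this carbon. Nothing measured here explains why these numbers lie as they do.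

Every group shown at this carbon is a six-membered aromatic ring, so it remains open whether a group of another kind there, such as a piperidine ring, a carboxylic acid or a longer alkyl chain, would give a number beyond the scatter. On these data alone, it also remains open whether this flat picture would hold if the acetyl group on the shared core were exchanged for another group.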